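Urea aryl variation on the shared core: compound 4

This account rests on a few compounds, and the source may have more. Where it says the series, first, only, none or still open, it means among the compounds named here.

Measured so far in a functional assay on HepG2 cells (Homo sapiens) for antiproliferative activity, read by MTT assay; a higher number here means a weaker inhibitor, a lower number a stronger inhibitor:
- compound 1, `Cc1ccccc1NC(=O)Nc1cccc(CNc2ncnc3ccccc23)c1`: reported only as a limit, > 50000 nM
- compound 2, `COc1ccccc1NC(=O)Nc1cccc(CNc2ncnc3ccccc23)c1`: 17500 nM
- compound 3, `CC(C)(C)c1ccc(NC(=O)Nc2cccc(CNc3ncnc4ccccc34)c2)cc1`: 17000 nM

Compound 3 holds the lowest number of the two compounds with a number, but the gap to compound 2 is within the scatter, so the two cannot be ordered. The value of compound 1 is a limit of this assay the limit of > 50000 nM in this assay, at which 1 of the 3 values shown sits, and not a number.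

Compound 4 is `O=C(Nc1cccc(CNc2ncnc3ccccc23)c1)Nc1ccccc1Cl`. It differs from compound 3 by 2-chlorophenyl in place of 4-(tert-butyl)phenyl on an amide-type nitrogen. Among the compounds with values here, two measured steps bear on this change, both involving a change of the aryl group on the same amide-type nitrogen. The step of an at least 2.9-fold lower number from compound 1 to compound 3 (0.46 log units; beyond the scatter) shows that moving from a 2-substituted aryl to the 4-(tert-butyl)phenyl lowered the number at least modestly; the step of a 1.0-fold lower number from compound 2 to compound 3 (0.01 log units; within the scatter) shows no change beyond the scatter for the other 2-substituted aryl. The reverse direction of the first step and the flat second step together point to a number for compound 4 that is expected to be somewhat higher than that of compound 3, with a step of a 1.8-fold higher number from compound 3 to compound 4 (0.25 log units; within the scatter) expected. Compound 4 is therefore estimated at 30000 nM, with a range from 12000 nM to 80000 nM, and a real chance that this assay reports only a limit.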

Compound 4, half-maximal inhibitory concentration: > 50000 nM
Compound 4: only a limit was reported; the forecaster's own chance of this, stated with the estimate: 35%; at least 1.6-fold (0.22 log units) between middle value and limit.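

In this assay, 2-chlorophenyl in place of 4-(tert-butyl)phenyl on the amide-type nitrogen gives an at least 2.9-fold higher number from compound 3 to compound 4 (0.46 log units; beyond the scatter), and chloro in place of methoxy on the aromatic carbon gives an at least 2.8-fold higher number from compound 2 to compound 4 (0.45 log units; beyond the scatter); both steps are open-ended, since one end of each is a limit and not a number. The aromatic carbon carrying methoxy, methyl or chloro therefore does not tolerate these groups alike: among the three 2-substituted aryl compounds, compound 2 alone has a number, and it goes against the otherwise shared outcome of compound 1 and compound 4. The step between those two limit compounds cannot be read, so methyl and chloro cannot be ordered, and the series now has a substantial share of its values at the assay limit: the limit of > 50000 nM in this assay, at which 2 of the 4 values shown sit.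

How far compound 4 lies beyond its limit remains unknown, and no cause for the step can be drawn from these compounds. Also open, on these data alone, is whether an amine or a carboxylic acid in place of chloro on the same aromatic carbon would give a number in this assay.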